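The source may hold more compounds than are shown below. What is called first, only, known or untested is meant among the compounds shown, and "the series" means these compounds.

Three compounds share one core and differ only in a single substituent on an aromatic carbon. Compound 1 `O=S(=O)(c1ccccc1)c1nc2ccccc2nc1N1CCCC1` carries hydrogen at that position, compound 2 `O=S(=O)(c1ccc(Br)cc1)c1nc2ccccc2nc1N1CCCC1` carries bromo, and compound 3 `O=S(=O)(c1ccc(F)cc1)c1nc2ccccc2nc1N1CCCC1` carries fluoro. In a functional assay on HCT-116 cells (Homo sapiens) for cytotoxicity, read by MTT assay, with a stated time of 72 h (on this read-out higher numbers stand for weaker inhibition and lower numbers for stronger inhibition), compound 1 gives 24200 nM, compound 2 gives 37700 nM, and compound 3 gives 20600 nM. The steps among them are small: a 1.6-fold higher number from compound 1 to compound 2 (0.19 log units; within the scatter), a 1.2-fold lower number from compound 1 to compound 3 (0.07 log units; within the scatter) and a 1.8-fold lower number from compound 2 to compound 3 (0.26 log units; within the scatter). Compound 3 thus sits alongside the other two, with all three numbers inside the scatter of one another and all pointing to weak inhibition.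

Compound 4 `O=S(=O)(c1ccc(F)cc1)c1nc2ccccc2nc1N1CCC(O)CC1` keeps the fluoro substituent of compound 3 but replaces the pyrrolidin-1-yl group: 4-hydroxypiperidin-1-yl in place of pyrrolidin-1-yl on an aromatic carbon. Among the compounds with values here, none of the measured steps touches this part of the molecule; each concerns only the substituent on the other aromatic carbon, so nothing measured bears directly on this change. Since the measured changes produced no step beyond the scatter, the working expectation is that compound 4 stays in the same weak region, and no step beyond the scatter in this assay is predicted with confidence. Compound 4 is therefore estimated at 25000 nM, with a range from 8000 nM to 80000 nM. The expected step is a 1.2-fold higher number from compound 3 to compound 4 (0.08 log units; within the scatter).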

Compound 4, half-maximal inhibitory concentration: 1340 nM
Beside the measured number, compound 4's estimate is 19-fold (1.27 log units) above it; the whole stated range lies above it.
By their numbers in this assay, from the lowest: compound 4; then compounds 3, 1 and 2 (each within the scatter of the next).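

In this assay, within the data shown here, the group on the aromatic carbon next to the ring nitrogen turns out to matter far more than the earlier compounds could suggest: 4-hydroxypiperidin-1-yl in place of pyrrolidin-1-yl gives a 15-fold lower number from compound 3 to compound 4 (1.19 log units; beyond the scatter). Swapping hydrogen, bromo and fluoro on the other aromatic ring produced only steps within the scatter, so this is the first change shown here to move the number clearly, and it brings the series out of the weak region in which compounds 1, 2 and 3 sit. The swap alters two things at once, a five-membered ring becoming a six-membered ring and a hydroxyl group being added, and nothing available explains how either one relates to the result.

The compounds shown leave open which of these two alterations carries the step, a question that plain piperidin-1-yl or 3-hydroxypyrrolidin-1-yl at this position could help separate. Also open, from the compounds shown here alone, is whether other groups here, such as morpholin-4-yl or 4-aminopiperidin-1-yl, behave like 4-hydroxypiperidin-1-yl, and whether the step holds with hydrogen or bromo in place of fluoro.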